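A fluorophenyl variant of a triazole-linked diaryl urea

The source may hold more compounds than are shown below. What is called first, only, known or untested is meant among the compounds shown, and "the series" means these compounds.

Compound 1 `Cc1cccc(-n2cc(COc3cccc(NC(=O)Nc4ccc(Cl)c(C(F)(F)F)c4)c3)nn2)c1` has the highest number of the three measured compounds in this set: in a functional assay on HepG2 cells (Homo sapiens) for inhibition, read by MTT assay, with a stated time of 72 h (on this read-out higher numbers stand for weaker inhibition and lower numbers for stronger inhibition), compound 1 gives 7270 nM. Its nearest neighbour is compound 2 `N#Cc1cccc(-n2cc(COc3cccc(NC(=O)Nc4ccc(Cl)c(C(F)(F)F)c4)c3)nn2)c1`, which in this assay gives 2760 nM; the step is a 2.6-fold lower number from compound 1 to compound 2 (0.42 log units; beyond the scatter). Furthest away is compound 3 `CC(C)c1ccc(-n2cc(COc3cccc(NC(=O)Nc4ccc(Cl)c(C(F)(F)F)c4)c3)nn2)cc1`, which in this assay gives 2470 nM; that step is a 2.9-fold lower number from compound 1 to compound 3 (0.47 log units; beyond the scatter). Their own difference, a 1.1-fold lower number from compound 2 to compound 3 (0.05 log units; within the scatter), lies within the scatter.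

Compound 4 `O=C(Nc1cccc(OCc2cn(-c3ccc(F)cc3)nn2)c1)Nc1ccc(Cl)c(C(F)(F)F)c1` differs from compound 1 in one place: 4-fluorophenyl in place of 3-methylphenyl on an aromatic nitrogen. Within the data shown here, no measured step introduces exactly this group, but both steps that replace the group on that aromatic nitrogen, a 2.6-fold lower number from compound 1 to compound 2 (0.42 log units; beyond the scatter) and a 2.9-fold lower number from compound 1 to compound 3 (0.47 log units; beyond the scatter), lowered the number modestly and beyond the scatter. One would therefore expect a step of similar modest size in the same direction, a 1.9-fold lower number from compound 1 to compound 4 (0.28 log units; within the scatter), while a change within the scatter cannot be excluded. Compound 4 is estimated at 3800 nM, with a range from 1700 nM to 8500 nM.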

Compound 4, half-maximal inhibitory concentration: 1350 nM
Compound 4: the middle estimate sits 2.8-fold (0.45 log units) above what was measured; the measured number lies below the stated range.
By their numbers in this assay, from the lowest: compounds 4, 3 and 2 (each within the scatter of the next, the first and the last beyond it); then compound 1.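

Replacing 3-methylphenyl on the aromatic nitrogen with 4-fluorophenyl gives the widest gap yet from compound 1 in this assay (a 5.4-fold lower number from compound 1 to compound 4 (0.73 log units; beyond the scatter)), so a third, different aryl group at this position also lowers the number. Compound 4 separates from compound 2 (a 2.0-fold lower number from compound 2 to compound 4 (0.31 log units; beyond the scatter)) but cannot be told apart from compound 3 (a 1.8-fold lower number from compound 3 to compound 4 (0.26 log units; within the scatter)), which leaves the two at a similar level. Nothing measured here explains these steps.

As far as these compounds go, the step from 3-methylphenyl to 4-fluorophenyl changes both the substituent and its place on the phenyl ring, so the contribution of each stays open. From the compounds shown here alone, it also stays open whether a chloro or methoxy group, an amine or a carboxylic acid on that ring would behave like the fluoro group of compound 4.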